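The source may hold more compounds than are shown below. What is called first, only, known or untested is meant among the compounds shown, and "the series" means these compounds.

Measured compounds, all in a functional assay on HEp-2 cells (Homo sapiens) for antiproliferative activity, read by MTT assay, with a stated time of 72 h; on this read-out higher numbers stand for weaker inhibition and lower numbers for stronger inhibition:
- compound 1 `COc1ccc2oc(CSC(=S)N(C(C)C)C(C)C)cc(=O)c2c1` gives 7600 nM
- compound 2 `Cc1ccc2c(=O)c(CSC(=S)N3CCCC3)coc2c1` gives 3600 nM
- compound 3 `Cc1ccc2c(=O)c(CSC(=S)N(C(C)C)C(C)C)coc2c1` gives 700 nM

Compound 3 has the lowest number of the three, and both gaps to the other two compounds lie beyond the usual scatter, so within this small set it is the strongest inhibitor of the cell growth measured in this assay. Compound 2 shares its core and differs only in the amine on the thiocarbonyl carbon; the step of a 5.1-fold lower number from compound 2 to compound 3 (0.71 log units; beyond the scatter) shows that exchanging the ring amine pyrrolidin-1-yl for the open-chain diisopropylamino gave a markedly lower number. Compound 1 has a different substituent on the core and is not directly comparable on this point.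

Compound 4 `Cc1ccc2c(=O)c(CSC(=S)N3CCOCC3)coc2c1` takes compound 3 back toward a ring amine: morpholin-4-yl in place of diisopropylamino on a thiocarbonyl carbon. For the measured compounds named here, the only measured step that bears on this change is the one from compound 2 to compound 3, where the ring amine gave the higher number. Morpholin-4-yl is, like pyrrolidin-1-yl, a ring amine on the same thiocarbonyl carbon, so the step is expected to go in the opposite direction, toward a higher number, and to be of roughly similar size, a 5.7-fold higher number from compound 3 to compound 4 (0.76 log units; beyond the scatter). In this assay compound 4 is therefore estimated at about 4000 nM, with a likely range from 1500 nM to 12000 nM.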

Compound 4, half-maximal inhibitory concentration: 4000 nM
The estimate for compound 4 equals the measured number at the digits printed; low and high end bracket the measured number.
By their numbers in this assay, from the lowest: compound 3; then compounds 2, 4 and 1 (each within the scatter of the next, the first and the last beyond it).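

In this assay the change on the thiocarbonyl carbon now has a second example: morpholin-4-yl in place of diisopropylamino gives a 5.7-fold higher number from compound 3 to compound 4 (0.76 log units; beyond the scatter), so the low number of compound 3 stands out against more than one ring amine. The two ring amines themselves cannot be told apart, since morpholin-4-yl in place of pyrrolidin-1-yl gives a 1.1-fold higher number from compound 2 to compound 4 (0.05 log units; within the scatter), and on this shared core the open-chain diisopropylamino therefore stands apart from both, with none of the three compounds going against that. No measurement here explains why this group gives the lower number.

Going by these compounds, what remains open is whether it is the open chain or the branching of diisopropylamino that goes with the lower number, which a smaller open-chain group such as diethylamino or an unbranched one such as dipropylamino could help to separate. A further ring amine such as piperidin-1-yl would also show whether ring amines on this core stay together at the higher numbers seen for compound 2 and compound 4.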